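Working notes: from compound 3 to compound 4

This account rests on a few compounds, and the source may have more. Where it says the series, first, only, none or still open, it means among the compounds named here.

Values from a physicochemical assay for permeability, using PAMPA (a lower number here means that the compound crosses the layer more slowly, a higher number that the compound crosses the layer faster), for the series are as follows:
- compound 1 `O=C(O)CCn1c(=O)oc2cc(OCc3ccccc3)c(Cl)cc21` gives "not determined" (no result reported)
- compound 2 `CC(C)Cc1cc2oc(=O)n(CCC(=O)O)c2cc1Cl` gives < 10 nm/s (a limit)
- compound 3 `C[C@@H](Oc1cc2oc(=O)n(CCC(=O)O)c2cc1Cl)c1cccnn1` gives < 3 nm/s (a limit)

Compound 3 stands at < 3 nm/s as a limit of the assay and not a number. Within the data shown here, the series offers no measured number in this assay so far, and compound 1 adds no result. Among the measured compounds shown here, no step between two measured compounds exists to calibrate the next one.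

The next compound is compound 4 `O=C(O)CCn1c(=O)oc2cc(OCC3CC3)c(Cl)cc21`, still unmeasured. The change a group of 4 heavy atoms (4 carbon; one three-membered non-aromatic ring of carbon only) in place of a group of 8 heavy atoms (6 carbon, 2 nitrogen; one six-membered aromatic ring with 2 hetero atoms), on an oxygen on an aromatic ring brings in cyclopropylmethyl in place of the larger group, on an oxygen on an aromatic ring.

Compound 2 also has no six-membered aromatic ring with 2 hetero atoms, yet its result of < 10 nm/s is a limit as well. This gives only weak support for a rise, so a small upward change, or none beyond the scatter, is expected in this assay for this replacement. The expected change is an at least 1.6-fold higher number from compound 3 to compound 4 (0.22 log units; that floor lies within the scatter) and rests on limits alone.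

For compound 4 the estimated value is 5 nm/s with an expected range from 1.5 nm/s to 20 nm/s if a number is reported at all.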

Compound 4, apparent permeability: 19 nm/s
Compound 4: the middle estimate sits 3.8-fold (0.58 log units) below what was measured, within the range that was stated.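

Among these compounds, compound 4 gives the first actual number of the series in this assay, at 19 nm/s, so later changes can now be read against a measured value. On an oxygen on an aromatic ring, cyclopropylmethyl in place of the group bearing the six-membered aromatic ring with 2 hetero atoms gives an at least 6.3-fold higher number from compound 3 to compound 4 (0.80 log units; beyond the scatter), which shows that the group at this position can shift the read-out beyond the scatter. Cyclopropylmethoxy in place of isobutyl on an aromatic carbon gives an at least 1.9-fold higher number from compound 2 to compound 4 (0.27 log units; that floor lies within the scatter), and with that floor within the scatter, this pair establishes no firm difference between the two groups.

On these data alone, each step starts from a limit and not from a number, so its full size stays open, and the step from compound 3 to compound 4 changes ring type and group size together. As far as these compounds go, how a plain n-butyl chain, or an aminoethyl group, on that same oxygen would read in this assay remains open, as does the effect of a primary amide in place of the carboxylic acid.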